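Chloro for Hydrogen on a Fused Aromatic Ring

This account rests on a few compounds, and the source may have more. Where it says the series, first, only, none or still open, it means among the compounds named here.

Compound 1 `Cc1cnc(Nc2ccc(S(C)(=O)=O)cc2)nc1Nc1nc2ccc(Cl)cc2s1`: 5900 nM
Compound 2 `Cc1cnc(Nc2ccc(S(C)(=O)=O)cc2)nc1Nc1nc2ccccc2s1`: 14800 nM
Compound 3 `NS(=O)(=O)c1ccc(Nc2ncc(F)c(Nc3nc4ccccc4s3)n2)cc1`: 22600 nM

Of the compounds shown here, three have been measured in a functional assay on MDA-MB-231 cells (Homo sapiens) for antiproliferative activity, read by MTT assay, with a stated time of 48 h; a lower number here means a stronger inhibitor, a higher number a weaker inhibitor. Compound 1 and compound 2 share one core and differ in a single place: chloro in place of hydrogen on an aromatic carbon. This change produced a 2.5-fold lower number from compound 2 to compound 1 (0.40 log units; beyond the scatter). Compound 3 is built on another core, and the difference between the two cores is not broken down here. Among the three numbers, compound 3 stands highest; its value lies nearest to that of compound 2, within the usual scatter, and furthest from that of compound 1, beyond the scatter.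

Compound 4 `NS(=O)(=O)c1ccc(Nc2ncc(F)c(Nc3nc4ccc(Cl)cc4s3)n2)cc1` has not yet been measured in this assay. It differs from compound 3 by chloro in place of hydrogen on an aromatic carbon. This is the same change that separates compound 2 from compound 1, and the place on the ring is described in exactly the same words for both pairs; among the compounds shown, the change occurs twice in all. A step of a similar size is expected, because a 2.5-fold lower number from compound 2 to compound 1 (0.40 log units; beyond the scatter) was seen on the other core, giving an estimated 2.4-fold lower number from compound 3 to compound 4 (0.38 log units; beyond the scatter). Whether the new core responds the same way is not known from the measured data, so the range is kept wide. Compound 4 is therefore expected to give about 9500 nM in this assay, most likely falling between 4000 nM and 22000 nM.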

Compound 4, half-maximal inhibitory concentration: 2790 nM
Beside the measured number, compound 4's estimate is 3.4-fold (0.53 log units) above it; the whole stated range lies above it.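

In this assay chloro in place of hydrogen on an aromatic carbon again gives an 8.1-fold lower number from compound 3 to compound 4 (0.91 log units; beyond the scatter) and so the direction of the change carries over from one core to the other. The size of the step does not carry over, and the two steps stand clearly apart: the same change on two cores in this assay, a 2.5-fold lower number (0.40 log units; beyond the scatter) from compound 2 to compound 1 and an 8.1-fold lower number (0.91 log units; beyond the scatter) from compound 3 to compound 4, 3.2-fold (0.51 log units) apart, beyond the scatter of two such steps. This does not show which difference between the two cores goes with the larger step: the cores differ in more than one place, the pairs shown do not separate those differences, and two pairs set no rule for any further core in the series.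

The compounds shown leave open whether another group on the same aromatic carbon, such as bromo, methoxy or an amine, would give a step like either of these, and whether chloro elsewhere on the six-membered aromatic ring would do the same. They also leave open how large the step would be on a core that carries only one of the differences between the two cores, which would show what part of the gap belongs to each difference.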